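The source may hold more compounds than are shown below. What is called first, only, known or untested is meant among the compounds shown, and "the series" means these compounds.

Three analogues share one core and differ only in the aryl group on the carbonyl carbon: compound 1 `N#Cc1cccc(C(=O)NC(=S)N2CCc3c(OCCCCCOc4ccc(Cl)cc4)cccc32)c1`, compound 2 `N#Cc1ccc(C(=O)NC(=S)N2CCc3c(OCCCCCOc4ccc(Cl)cc4)cccc32)cc1` and compound 3 `O=C(NC(=S)N1CCc2c(OCCCCCOc3ccc(Cl)cc3)cccc21)c1ccc(Br)cc1`. In an ADME assay on Huh-7 cells (Homo sapiens) for cytotoxicity (a lower number here means that less compound is tolerated, a higher number that more compound is tolerated), compound 1 gives 9750 nM, and compound 3 gives 29100 nM, the higher of the two numbers. For compound 2 this assay returns only a limit, > 50000 nM. The aryl changes moved the read-out: an at least 5.1-fold higher number from compound 1 to compound 2 (0.70 log units; beyond the scatter) and a 3.0-fold higher number from compound 1 to compound 3 (0.47 log units; beyond the scatter), whereas an at least 1.7-fold lower number from compound 2 to compound 3 (0.23 log units; that floor lies within the scatter). Compound 4 `O=C(NC(=S)N1CCc2c(OCCCCCOc3ccc(Cl)cc3)cccc21)c1ccc(C(F)(F)F)cc1` differs from compound 3 by trifluoromethyl in place of bromo on an aromatic carbon. Going by the values given here, no measured step exchanges bromo for trifluoromethyl, and the nearest comparison, bromo against cyano, stayed within the scatter, so a step of at most a 1.0-fold higher number from compound 3 to compound 4 (0.01 log units; within the scatter) is expected. Compound 4 is estimated in this assay at 30000 nM, between 12000 nM and 80000 nM.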

Compound 4, half-maximal cytotoxic concentration: 32700 nM
The estimate for compound 4 lay 1.1-fold (0.04 log units) below the measured number, and the stated range covers the measured number.
By their numbers in this assay, from the lowest: compound 1; then compounds 3 and 4 (each within the scatter of the next). At a limit, above all of these: compound 2.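

In this assay, trifluoromethyl and bromo on this aromatic carbon are not told apart: a 1.1-fold higher number from compound 3 to compound 4 (0.05 log units; within the scatter). The 4-(trifluoromethyl)phenyl group also stands clear of the 3-cyanophenyl group, a 3.4-fold higher number from compound 1 to compound 4 (0.53 log units; beyond the scatter), as the 4-bromophenyl and 4-cyanophenyl groups already did. Against the nitrile the picture stays unresolved, an at least 1.5-fold lower number from compound 2 to compound 4 (0.18 log units; that floor lies within the scatter), and that comparison rests on a limit: the limit of > 50000 nM in this assay, at which 1 of the 4 values shown sits.

Open, on these data alone, is how an amine or a carboxylic acid would read on this aromatic carbon. Also open, as far as these compounds go, is how far compound 2 actually lies from compound 4.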